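Dimethylamino in place of pyrrolidin-1-yl in compound 2

This account rests on a few compounds, and the source may have more. Where it says the series, first, only, none or still open, it means among the compounds named here.

Measured in a functional assay on MCF7 cells (Homo sapiens) for antiproliferative activity, read by MTT assay, with a stated time of 48 h; on this read-out lower numbers stand for stronger inhibition and higher numbers for weaker inhibition:
Compound 1 `CCN(CC)CC(=O)Nc1ccc(Nc2cc(Cl)nc(-c3ccc(OC)cc3)n2)cc1` gives > 40000 nM, which is a limit.
Compound 2 `COc1ccc(-c2nc(Cl)cc(Nc3ccc(NC(=O)CN4CCCC4)cc3)n2)cc1` gives 23400 nM.
Compound 3 `COc1ccc(-c2nc(Cl)c(-c3ccccc3)c(Nc3ccc(NC(=O)CN4CCCC4)cc3)n2)cc1` gives > 40000 nM, which is a limit.

Compound 2 stands alone in this small set with an actual number, 23400 nM. The other two results are limits of the assay. The next structure is compound 4 `COc1ccc(-c2nc(Cl)cc(Nc3ccc(NC(=O)CN(C)C)cc3)n2)cc1`, and the change to it reads (dimethylamino in place of pyrrolidin-1-yl on a saturated chain carbon bound to a carbonyl carbon). In words, this is dimethylamino in place of pyrrolidin-1-yl on a saturated chain carbon bound to a carbonyl carbon.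

The closest measured change sits at that same place, where diethylamino gives way to pyrrolidin-1-yl. With only an at least 1.7-fold lower number from compound 1 to compound 2 (0.23 log units; that floor lies within the scatter) to go on, no step beyond the scatter is expected in this assay. The other measured change, an at least 1.7-fold higher number from compound 2 to compound 3 (0.23 log units; that floor lies within the scatter), is phenyl in place of hydrogen on an aromatic carbon, a different exchange that bears little on this one.

The expected step is a 1.2-fold higher number from compound 2 to compound 4 (0.08 log units; within the scatter). Compound 4 is estimated at 28000 nM, with an expected range from 12000 nM to 60000 nM. It is also expected that compound 4 could be reported only as a limit.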

Compound 4, half-maximal inhibitory concentration: > 40000 nM
Compound 4: a limit, no number; the forecaster's own chance of this, stated with the estimate: 40%; middle value at least 1.4-fold (0.15 log units) from the limit.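

In this assay, moving from pyrrolidin-1-yl to dimethylamino on the saturated chain carbon bound to a carbonyl carbon gives an at least 1.7-fold higher number from compound 2 to compound 4 (0.23 log units; that floor lies within the scatter), so this floor alone does not establish a real loss of activity. Compound 1 and compound 4 carry the two open-chain amines, diethylamino and dimethylamino, and both end as limits, so the step between them cannot be read; among the compounds that differ only at this place, compound 2 with its pyrrolidin-1-yl ring is the only one that gives an actual number, although compound 3 keeps that ring and still ends as a limit. How far the open-chain amines truly lie from compound 2 stays hidden, and the read-out is bounded by one value: the limit of > 40000 nM in this assay, at which 3 of the 4 values shown sit.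

As far as these compounds go, whether a larger ring at this place, such as piperidin-1-yl or morpholin-4-yl, would give an actual number remains open. So does the question of whether a primary amine or a longer chain between the carbonyl and the amine would move the result in either direction.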